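Swapping the Aryl Group on the Saturated Ring Carbon

The source may hold more compounds than are shown below. What is called first, only, known or untested is meant among the compounds shown, and "the series" means these compounds.

Compound 2 `COc1cc(C)c(Cl)cc1C1=NN(c2ccc(S(N)(=O)=O)cc2)C(c2ccc(N(C)C)cc2)C1` gives 95.2% in a functional assay on the whole organism (strain Wistar) for inhibition, with Rattus norvegicus as the target, read by paw edema, with stated times of 30 min and 5 h, at a dose of 20 mg/kg by the oral route (on this read-out lower numbers stand for less inhibition and higher numbers for more inhibition at the one dose given (going by the name of the read-out)), the higher of the two numbers measured; compound 1 `COc1cc(C)c(Cl)cc1C1=NN(c2ccc(S(N)(=O)=O)cc2)C(c2ccccc2)C1` gives 59.5%. For the measured compounds named here, the only measured step, a number 35.7 percentage points higher from compound 1 to compound 2 (beyond the scatter), sits at the same saturated ring carbon. Compound 3 `COc1cc(C)c(Cl)cc1C1=NN(c2ccc(S(N)(=O)=O)cc2)C(c2ccc(OC)c(OC)c2OC)C1` carries 2,3,4-trimethoxyphenyl in place of 4-(dimethylamino)phenyl on a saturated ring carbon. Going by the values given here, no measured step covers this exchange directly: the one step shows a substituted phenyl at this carbon well above a bare phenyl, yet tells nothing about one substituted phenyl against another. The step of a number 20.2 percentage points lower from compound 2 to compound 3 (beyond the scatter) is therefore expected to be a modest decrease, with wide uncertainty. Compound 3 is estimated at 75%, between 50% and 95%.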

Compound 3, a percentage reported as inhibition, in the whole organism at one dose (the size of the read-out at that dose, not a potency): 21.4%
The estimate for compound 3 lay 53.6 percentage points above the measured number; measured number outside the range, below it.
By their numbers in this assay, from the lowest: compound 3; then compound 1; then compound 2.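

On this saturated ring carbon, 2,3,4-trimethoxyphenyl gives a number 73.8 percentage points lower from compound 2 to compound 3 (beyond the scatter) and a number 38.1 percentage points lower from compound 1 to compound 3 (beyond the scatter) in this assay. A substituted phenyl here can therefore fall below the bare phenyl as well as rise above it, so the gain seen with 4-(dimethylamino)phenyl does not extend to every substituted phenyl. Nothing available explains this reversal.

The compounds shown leave open whether a single methoxy group, as in 4-methoxyphenyl, would behave like the trimethoxyphenyl group. They also leave open whether a primary amine, as in 4-aminophenyl, would match 4-(dimethylamino)phenyl.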